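This account rests on a few compounds, and the source may have more. Where it says the series, first, only, none or still open, it means among the compounds named here.

Measured in an ADME assay on HepG2 2.2.15 cells (Homo sapiens) for cytotoxicity; a lower number here means that less compound is tolerated, a higher number that more compound is tolerated:
- compound 1 `O=C(OCCc1c(-c2ccccc2Cl)c2cc(Cl)ccc2[nH]c1=O)C1CCCCC1`: 38000 nM
- compound 2 `COc1ccccc1/C=C/C(=O)OCCc1c(-c2ccccc2Cl)c2cc(Cl)ccc2[nH]c1=O`: 770000 nM

Of the two measured compounds, compound 2 has the higher number, 770000 nM. The next compound, compound 3 `O=C(/C=C/c1cccnc1)OCCc1c(-c2ccccc2Cl)c2cc(Cl)ccc2[nH]c1=O`, differs from it as follows: pyridin-3-yl in place of 2-methoxyphenyl on a double-bonded chain carbon bound to a double-bonded chain carbon. In words, this is pyridin-3-yl in place of 2-methoxyphenyl on a double-bonded chain carbon bound to a double-bonded chain carbon.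

Among the compounds with values here, only one measured step bears on this change, and only indirectly: a 20-fold higher number from compound 1 to compound 2 (1.31 log units; beyond the scatter). This large step replaced cyclohexyl with 2-(2-methoxyphenyl)ethenyl on a carbonyl carbon. Within the data shown here, the new change keeps the ethenyl chain and alters only the aromatic ring at its end, and no measured step isolates a change of that kind. A much smaller step than the measured one is therefore expected in this assay, probably with no move beyond the scatter and a slight lean toward a lower number. The expected move is a 1.9-fold lower number from compound 2 to compound 3 (0.28 log units; within the scatter). For compound 3 the estimated value is 400000 nM, with an expected range of 100000 nM to 1000000 nM.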

Compound 3, half-maximal cytotoxic concentration: 39000 nM
Estimate against measurement, compound 3: 10-fold (1.01 log units) above; measured number below the stated range.
By their numbers in this assay, from the lowest: compounds 1 and 3 (each within the scatter of the next); then compound 2.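

In this assay, the aromatic ring at the end of the ethenyl chain proves decisive at this position: exchanging 2-methoxyphenyl for pyridin-3-yl gives a 20-fold lower number from compound 2 to compound 3 (1.30 log units; beyond the scatter). The ethenyl chain alone therefore does not go with the high number seen for compound 2, since replacing cyclohexyl with 2-(pyridin-3-yl)ethenyl on the carbonyl carbon gives a 1.0-fold higher number from compound 1 to compound 3 (0.01 log units; within the scatter), which lies within the scatter. Among the three compounds, the high number is thus tied to the 2-(2-methoxyphenyl)ethenyl group as a whole, and no measurement at hand gives a reason for this difference.

The step from 2-methoxyphenyl to pyridin-3-yl changes the ring and removes the methoxy group at once, so the compounds shown do not separate the contribution of the methoxy group from that of the ring nitrogen. A plain phenyl on the same ethenyl chain would help separate the two, and a pyridin-3-yl ring bearing a methoxy group would show whether that group restores the high number in this ring.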